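This account rests on a few compounds, and the source may have more. Where it says the series, first, only, none or still open, it means among the compounds named here.

Within the data shown here, compound 2 `Clc1cccc(-c2nc(N3CCCCC3)c3nc[nH]c3n2)c1` stands with the highest of the two numbers measured so far. Among the measured compounds shown here, in an assay on cells for displacement of a labelled ligand from adenosine receptor A3 (Homo sapiens), read by scintillation counting and radioligand binding, with a stated time of 180 min (a higher number here means a weaker inhibitor, a lower number a stronger inhibitor), compound 2 gives 39.8 nM, whereas compound 1 `Clc1ccc(-c2nc(N3CCCCC3)c3nc[nH]c3n2)cc1` gives 7.94 nM; that one measured step, a 5.0-fold higher number from compound 1 to compound 2 (0.70 log units; beyond the scatter), is the only guide here. Compound 3 `Oc1ccc(-c2nc(N3CCCCC3)c3nc[nH]c3n2)cc1` has not been measured; it carries 4-hydroxyphenyl in place of 3-chlorophenyl on an aromatic carbon. Returning to a substituent on a 4-chlorophenyl-like position helped compound 1, but nothing shows how hydroxyl compares with chlorine, so the step of a 2.7-fold lower number from compound 2 to compound 3 (0.42 log units; beyond the scatter) is expected to be modest and downward, with wide uncertainty. Compound 3 is therefore estimated at 15 nM, between 3 nM and 80 nM.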

Compound 3, inhibition constant: 39.8 nM
Estimate against measurement, compound 3: 2.7-fold (0.42 log units) below, and the stated range covers the measured number.
By their numbers in this assay, from the lowest: compound 1; then compounds 2 and 3 (each within the scatter of the next).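

In this assay, hydroxy in place of chloro on the same carbon gives a 5.0-fold higher number from compound 1 to compound 3 (0.70 log units; beyond the scatter) and shows that this position responds to what the phenyl ring carries: here chloro cannot be swapped for hydroxy without a measurable loss. Replacing 3-chlorophenyl with 4-hydroxyphenyl gives no change at the digits printed from compound 2 to compound 3 (within the scatter) and shows that two groups differing in both substituent and placement can read alike. Nothing measured here explains either result. On these data alone, whether an amine or a methoxy group on that carbon would read like chloro or like hydroxy remains open. So does how 3-hydroxyphenyl would compare with 3-chlorophenyl.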